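Trading One Chain-End Amine for Another

This account rests on a few compounds, and the source may have more. Where it says the series, first, only, none or still open, it means among the compounds named here.

Compound 1 `CCN(CC)CCCOc1cc2ncnc(Nc3ccc(C#N)cc3)c2cc1OC` gives 50600 nM in a functional assay on A549 cells (Homo sapiens) for antiproliferative activity, read by MTT assay, with a stated time of 72 h; a higher number here means a weaker inhibitor, a lower number a stronger inhibitor.
Compound 2 `COc1cc2c(Nc3ccc(C#N)cc3)ncnc2cc1OCCCN(C)Cc1ccccc1` in this assay reaches only a limit, > 100000 nM.

Compound 2 therefore has no number of its own; it sits at the edge of what this assay can report, and that edge is described by the limit of > 100000 nM in this assay, at which 1 of the 2 values shown sits. Among the compounds with values here, the single measured step, an at least 1.9-fold higher number from compound 1 to compound 2 (0.29 log units; that floor lies within the scatter), is itself only a floor due to the limit of > 100000 nM in this assay, at which 1 of the 2 values shown sits, and tells no more than that swapping one tertiary amine for another at the end of the chain did not make the compound any stronger.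

Compound 3 `CCOC(=O)C1CCN(CCCOc2cc3ncnc(Nc4ccc(C#N)cc4)c3cc2OC)CC1` carries the change (4-(ethoxycarbonyl)piperidin-1-yl in place of benzyl(methyl)amino on a saturated chain carbon, three bonds along the chain from an oxygen on an aromatic ring). This is again an exchange of one neutral tertiary amine for another at the same chain position, so the step that bears on it is the one just described, and no movement beyond the scatter is expected; the step of an at least 1.2-fold lower number from compound 2 to compound 3 (0.09 log units; that floor lies within the scatter) is my estimate. Compound 3 is expected to give about 80000 nM in this assay, somewhere between 30000 nM and 200000 nM, with a real chance that only a limit is reported.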

Compound 3, half-maximal inhibitory concentration: 89900 nM
For compound 3 the middle estimate is 1.1-fold (0.05 log units) below the measured one, and the stated range covers the measured number.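

Within the data shown here, the step from diethylamino to 4-(ethoxycarbonyl)piperidin-1-yl, a 1.8-fold higher number from compound 1 to compound 3 (0.25 log units; within the scatter), is the first here with a real number at both ends. In this assay, a six-membered non-aromatic ring and two oxygen atoms can therefore enter at this place, on a saturated chain carbon three bonds along the chain from an oxygen on an aromatic ring, and the result stays within the scatter of compound 1. The other step, an at least 1.1-fold lower number from compound 2 to compound 3 (0.04 log units; that floor lies within the scatter), gives only a floor, as compound 2 has a limit and no number of its own: the limit of > 100000 nM in this assay, at which 1 of the 3 values shown sits.

The compounds shown leave open whether any group at this place can bring the number down by more than the scatter, for example a morpholine ring, a carboxylic acid in place of the ethoxycarbonyl, or a longer chain carrying the same amine. They also cannot tell how far compound 2 really lies from the other two compounds, so the effect of its benzyl(methyl)amino group remains unsized.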